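The compounds below may be only part of what the source reports. "The series", "measured", "known", "first", "only" and "open" are said of these compounds alone.

Compound 1, `CCOC(=O)c1c(-c2cccc(Cl)c2)[nH]c2cc(OC)ccc2c1=O`, in an ADME assay on Raji cells (Homo sapiens) for cytotoxicity, read by luminescence, with a stated time of 72 h (on this read-out lower numbers stand for an effect already at smaller amounts and higher numbers for an effect only at larger amounts of compound), gives > 21500 nM, a limit of the assay.
Compound 2, `CCOC(=O)c1c(-c2cccc(O)c2)[nH]c2cc(OC)ccc2c1=O`, in this assay gives > 21500 nM, again only a limit.
Compound 3, `CCOC(=O)c1c(-c2cccc(-c3ccccc3)c2)[nH]c2cc(O)ccc2c1=O`, in this assay gives > 21500 nM, also a limit.

All three values thus sit at the limit of > 21500 nM in this assay, at which 3 of the 3 values shown sit, and compound 3 is known only as a limit. The step that the two limits leave unreadable from compound 2 to compound 1 is one of chloro in place of hydroxy on an aromatic carbon. Compound 4, `CCOC(=O)c1c(-c2cccc(-c3ccccc3)c2)[nH]c2cc(Cl)ccc2c1=O`, is not yet measured; it differs from compound 3 by chloro in place of hydroxy on an aromatic carbon. This is the same kind of change as that from compound 2 to compound 1, but here it sits on a ring that is part of a fused or bridged system of two rings, meta to a fused ring and para to a fused ring, whereas there it sat meta to a large group. How the core of compound 3 differs from that of compound 2 is not broken down here. For compound 4 in this assay a step that the limit leaves unreadable from compound 3 to compound 4 is expected. This rests on compound 3 showing only the limit > 21500 nM. Compound 4 is therefore estimated at 30000 nM, most likely reported again only as a limit. Its expected range runs from 12000 nM to 100000 nM.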

Compound 4, half-maximal effective concentration: > 21500 nM
Compound 4: a limit, no number; the forecaster's own chance of this, stated with the estimate: 80%; the middle value lies beyond the limit too.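

Going by these compounds alone, compound 3 and compound 4 are both known only as limits, so no step between them can be read. The compounds shown leave open how chloro and hydroxy on an aromatic carbon compare in this assay.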